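Ring closure of the tertiary amine in compound 2

The compounds below may be only part of what the source reports. "The series", "measured", "known", "first", "only" and "open" are said of these compounds alone.

compound 1 `CCCCNc1nc(C(F)(F)F)ccc1CNC(=O)C(C)c1ccc(NS(C)(=O)=O)c(F)c1`: 9.1 nM
compound 2 `CCCCN(C)c1nc(C(F)(F)F)ccc1CNC(=O)C(C)c1ccc(NS(C)(=O)=O)c(F)c1`: 0.8 nM

In a functional assay on CHO-K1 cells for antagonist activity at transient receptor potential cation channel subfamily V member 1 (Homo sapiens), read by FLIPR (a higher number here means a weaker inhibitor, a lower number a stronger inhibitor), compound 2 gives 0.8 nM, the lowest of the two numbers; the nearest is compound 1 at 9.1 nM. Within the data shown here, the only measured step, an 11-fold lower number from compound 1 to compound 2 (1.06 log units; beyond the scatter), concerns methyl in place of hydrogen on the ring-attached nitrogen. Compound 3 `CC(C(=O)NCc1ccc(C(F)(F)F)nc1N1CCCC1)c1ccc(NS(C)(=O)=O)c(F)c1` keeps the tertiary nitrogen; the change is pyrrolidin-1-yl in place of butyl(methyl)amino on an aromatic carbon. Among the measured compounds shown here, no measured step covers an exchange of one tertiary amino group for another, so little movement is expected. Compound 3 is estimated at 1.5 nM, range 0.4 nM to 6 nM, a step of a 1.9-fold higher number from compound 2 to compound 3 (0.27 log units; within the scatter) expected within the scatter.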

Compound 3, inhibition constant: 0.6 nM
Compound 3: middle estimate off by 2.5-fold (0.40 log units), on the high side, within the range that was stated.
By their numbers in this assay, from the lowest: compounds 3 and 2 (each within the scatter of the next); then compound 1.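

In this assay, the step of a 1.3-fold lower number from compound 2 to compound 3 (0.12 log units; within the scatter) stays within the scatter, so at this position next to the ring nitrogen, pyrrolidin-1-yl and the open butyl(methyl)amino group cannot be told apart. The step of a 15-fold lower number from compound 1 to compound 3 (1.18 log units; beyond the scatter) lies beyond the scatter, so both tertiary amino groups in compounds 2 and 3 stand apart from the butylamino group of compound 1, and a ring serves as well as an open chain here. Nothing available accounts for this result.

Open, from the compounds shown here alone, is whether a piperidin-1-yl or morpholin-4-yl ring would hold the number at this position. Also open, going by these compounds, is how dimethylamino, with its shorter chains, would compare.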